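The source may report more compounds than this note shows. Statements on the series, on what has been measured and on what is new or still open speak of the compounds shown alone.

Compound 1 `CS(=O)(=O)OC1CCC(CN2CCN(c3cc(=O)c4cc(C(F)(F)F)cc([N+](=O)[O-])c4s3)CC2)CC1` and compound 2 `O=C(OC1CCC(CN2CCN(c3cc(=O)c4cc(C(F)(F)F)cc([N+](=O)[O-])c4s3)CC2)CC1)c1ccncc1` share one core and differ in a single place, (pyridin-4-yl)carbonyl in place of methylsulfonyl on an oxygen on a saturated carbon. In an ADME assay on Vero cells (Chlorocebus sabaeus) for cytotoxicity, read by MTT assay, with a stated time of 48 h (a higher number here means a weaker inhibitor, a lower number a stronger inhibitor), compound 1 gives only the limit > 64 ug/mL. In this assay compound 2 likewise gives only the limit > 64 ug/mL. The step that the two limits leave unreadable from compound 1 to compound 2 cannot be read because of the limit of > 64 ug/mL in this assay, at which 2 of the 2 values shown sit. Compound 3 `CC(=O)NC1CCC(CN2CCN(c3cc(=O)c4cc(C(F)(F)F)cc([N+](=O)[O-])c4s3)CC2)CC1` differs from compound 2 by acetamido in place of ((pyridin-4-yl)carbonyl)oxy on a saturated ring carbon. Both measured values sit at a limit, so no readable step bears on this exchange. Compound 3 is expected to give 80 ug/mL, between 40 ug/mL and 200 ug/mL, a step that the limit leaves unreadable from compound 2 to compound 3 estimated to stay within the scatter.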

Compound 3, half-maximal inhibitory concentration: > 64 ug/mL
Compound 3: only a limit was reported (the forecaster's own chance of this, stated with the estimate: 85%); the middle value is on the limit's open side.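

No step from compound 1 or compound 2 to compound 3 can be read in this assay, because all three compounds give the same limit: the limit of > 64 ug/mL in this assay, at which 3 of the 3 values shown sit.

The compounds shown leave open whether exchanging the group on the saturated ring carbon changes cytotoxicity at all.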